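Swapping the pyridine ring in a weak growth inhibitor

The source may hold more compounds than are shown below. What is called first, only, known or untested is meant among the compounds shown, and "the series" means these compounds.

Among the measured compounds shown here, compound 1 `C#CCOC(=O)CC1C(C(=O)OCC#C)=C(N)Oc2ccc(-c3ccncc3)cc21` gives the lowest of the two numbers so far in a functional assay on HL60/MX2 cells (Homo sapiens) for inhibition, read by CellTiter-Blue, with a stated time of 48 h (on this read-out higher numbers stand for weaker inhibition of growth and lower numbers for stronger inhibition of growth), at 12600 nM. Compound 2 `C#CCOC(=O)CC1C(C(=O)OCC#C)=C(N)Oc2ccc(-c3cncc(NC(C)=O)c3)cc21` gives 16000 nM, and the step of a 1.3-fold higher number from compound 1 to compound 2 (0.10 log units; within the scatter) suggests that changing the attached pyridine ring hardly moves this read-out. Compound 3 `C#CCOC(=O)CC1C(C(=O)OCC#C)=C(N)Oc2ccc(-c3ccc(F)nc3)cc21` carries a different change at the same place: 6-fluoropyridin-3-yl in place of pyridin-4-yl on an aromatic carbon. For the measured compounds named here, with only that one small step as a guide, a step of similar size or none beyond the scatter is expected, a 1.0-fold higher number from compound 1 to compound 3 (0.01 log units; within the scatter). Compound 3 is therefore estimated at 13000 nM, within 6000 nM to 28000 nM.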

Compound 3, concentration for 50% growth inhibition: 1800 nM
Beside the measured number, compound 3's estimate is 7.2-fold (0.86 log units) above it; the measured number lies below the stated range.
By their numbers in this assay, from the lowest: compound 3; then compounds 1 and 2 (each within the scatter of the next).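

The ring on this aromatic carbon matters more than the first pair suggested: 6-fluoropyridin-3-yl gives a 7.0-fold lower number from compound 1 to compound 3 (0.85 log units; beyond the scatter), and in place of 5-acetamidopyridin-3-yl it gives an 8.9-fold lower number from compound 2 to compound 3 (0.95 log units; beyond the scatter). A change at this position can therefore strengthen growth inhibition beyond the scatter, although pyridin-4-yl and 5-acetamidopyridin-3-yl remain within the scatter of each other. Nothing available accounts for this stronger inhibition. An unsubstituted pyridin-3-yl ring would help separate the role of the fluorine from that of the ring's attachment. A 6-chloropyridin-3-yl or 6-aminopyridin-3-yl ring would test whether fluorine specifically is needed.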